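Shifting Ring Substituents in a Bisacylhydrazine Agonist Series

The source may report more compounds than this note shows. Statements on the series, on what has been measured and on what is new or still open speak of the compounds shown alone.

Of the compounds shown here, three sharing one core have so far been tested in an assay on cells for agonist activity at ecdysone receptor (Bombyx mori), read by a luciferase reporter, with a stated time of 24 h; a lower number here means that less compound is needed, a higher number that more compound is needed for the effect. Compound 1 `CC(C)(C)N(NC(=O)c1ccccc1Br)C(=O)c1ccccc1Cl` gives 316 nM. Compound 2 `CC(C)(C)N(NC(=O)c1cccc(F)c1)C(=O)c1ccccc1Cl` gives 69.2 nM, and compound 3 `CCc1ccc(C(=O)NN(C(=O)c2ccccc2Cl)C(C)(C)C)cc1` gives 5.75 nM, the lowest of the three numbers: it stands at a 12-fold lower number from compound 2 to compound 3 (1.08 log units; beyond the scatter) and at a 55-fold lower number from compound 1 to compound 3 (1.74 log units; beyond the scatter). The step of a 4.6-fold lower number from compound 1 to compound 2 (0.66 log units; beyond the scatter) shows that exchanging the 2-bromophenyl for a 3-fluorophenyl already brought a clear gain.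

Compound 4 `Cc1cccc(C(=O)NN(C(=O)c2ccccc2Cl)C(C)(C)C)c1C` differs from compound 3 in one place: 2,3-dimethylphenyl in place of 4-ethylphenyl on a carbonyl carbon. Within the data shown here, no measured step changes one eight-carbon aryl group for another, so the bearing of the earlier steps is indirect. The largest jumps seen so far came from moving away from the 2-bromophenyl of compound 1, and compound 4 again carries a substituent on the same kind of ring, though a different one. Compound 4 is therefore expected to give a higher number than compound 3 in this assay, a step of about a 10-fold higher number from compound 3 to compound 4 (1.02 log units; beyond the scatter). The estimate for compound 4 is 60 nM, with a likely range from 15 nM to 250 nM.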

Compound 4, half-maximal effective concentration: 20 nM
Compound 4: the middle estimate sits 3.0-fold (0.48 log units) above what was measured, and the stated range covers the measured number.
By their numbers in this assay, from the lowest: compound 3; then compound 4; then compound 2; then compound 1.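

In this assay the change behind a 3.5-fold higher number from compound 3 to compound 4 (0.54 log units; beyond the scatter) keeps the atom count the same: 4-ethylphenyl and 2,3-dimethylphenyl each have 8 carbon atoms and one six-membered aromatic ring, so rearranging those carbons alone shifts the number at this place on a carbonyl carbon. The 2,3-dimethylphenyl group also stands apart from both halogen-bearing groups, with a 3.5-fold lower number from compound 2 to compound 4 (0.54 log units; beyond the scatter) and a 16-fold lower number from compound 1 to compound 4 (1.20 log units; beyond the scatter) and so 2-bromophenyl and 2,3-dimethylphenyl do not behave alike, even though both names begin with a 2. No measurement available here accounts for these steps.

A 4-propylphenyl or 3-ethylphenyl group at this place would help separate the effect of chain length from that of where the chain sits on the ring. As far as these compounds go, how this place would respond to a ring carrying an amine or a carboxylic acid also remains open.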